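This account rests on a few compounds, and the source may have more. Where it says the series, first, only, none or still open, it means among the compounds named here.

Three compounds have been measured in an assay for inhibition of methylcytosine dioxygenase TET2 (Homo sapiens), read by ELISA, with a stated time of 2 h; on this read-out higher numbers stand for weaker inhibition and lower numbers for stronger inhibition:

compound 1 `C=C(CC(C)(O)C(=O)O)C(=O)O`, 54800 nM
compound 2 `O=C(O)/C=C/C(=O)C(=O)O`, 107000 nM
compound 3 `C=C(C[C@@H](O)C(=O)O)C(=O)O`, 11000 nM

Compound 3 has the lowest number of the three; its value stands well apart from that of compound 1 and further still from that of compound 2. Compound 4 `C=C(C[C@H](O)C(=O)O)C(=O)O` differs from compound 3 only in configuration: the two compounds have the same atoms and bonds and differ only in configuration as drawn: 1 of 1 stereo elements differ; a stereocentre at a saturated chain carbon is drawn R in compound 3 and S in compound 4. Among the measured compounds shown here, no measured pair here shows what such a change alone does, so the expectation rests on compound 3 alone. Since the hydroxyl-bearing centre is the sole stereo element, the mirror-image compound 4 is expected to give a higher number in this assay, by a step of a 4.1-fold higher number from compound 3 to compound 4 (0.61 log units; beyond the scatter) that is likely beyond the scatter. The estimate for compound 4 is 45000 nM, with a range from 12000 nM to 170000 nM.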

Compound 4, half-maximal inhibitory concentration: 10500 nM
Compound 4: middle estimate off by 4.3-fold (0.63 log units), on the high side; measured number below the stated range.
By their numbers in this assay, from the lowest: compounds 4 and 3 (each within the scatter of the next); then compounds 1 and 2 (each within the scatter of the next).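

In this assay, the change of the stereocentre at a saturated chain carbon from R to S gives a 1.0-fold lower number from compound 3 to compound 4 (0.02 log units; within the scatter), so the configuration drawn at this position makes no readable difference in this assay. This is the only pair among the compounds shown that isolates a single change, and nothing else separates its two members: the fact that compounds 3 and 4 differ only in the configuration as drawn. From the compounds shown here alone, it remains open whether an amine or a fluorine in place of the hydroxyl on that carbon would leave the number unchanged. Going by these compounds, what a longer chain would do also remains open.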